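A few compounds are considered here, and "the series" means these few. Any claim that something is new, unique, unknown or untested is made for them only; others in the source may bear on it.

The study's shared core is the thiazolidinedione bearing an arylidene group, carried here by compound 1 `Cc1ccc(/C=C2\SC(=O)N(Cc3ccc(C)cc3)C2=O)cc1` and compound 2 `Cc1ccc(CN2C(=O)S/C(=C\c3ccc(O)cc3)C2=O)cc1`. In a functional assay on the whole organism (plasma) with Mus musculus as the target, with a stated time of 15 days, at a dose of 10 mg/kg by the oral route (a lower number here means a weaker effect, a higher number a stronger effect of the compound at the dose given), compound 1 gives 16.3%, and compound 2 gives 19.9%. For the measured compounds named here, of the two numbers so far, compound 1 has the lower one, but its nearest neighbour is within the scatter: the step of a number 3.6 percentage points higher from compound 1 to compound 2 (within the scatter) comes with hydroxy in place of methyl on an aromatic carbon, so the two compounds cannot be told apart on this evidence.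

Compound 3 `Cc1ccc(CN2C(=O)S/C(=C\c3cccc(Br)c3)C2=O)cc1` has not yet been measured in this assay. It differs from compound 1 as follows: 3-bromophenyl in place of 4-methylphenyl on a double-bonded chain carbon bound to a double-bonded ring carbon. Going by the values given here, the only measured step, from compound 1 to compound 2, changes the same aromatic ring but exchanges a different group, and it stayed within the scatter; no step that exchanges a whole aryl group has been recorded. The data therefore give no reason to expect a step beyond the scatter in this assay for compound 3, and the step of a number 0.7 percentage points higher from compound 1 to compound 3 (within the scatter) is an expectation of no real change. On that basis compound 3 is estimated at 17% in this assay, within a range from 4% to 32%.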

Compound 3, a percentage reported as activity, at one dose (the size of the read-out at that dose, not a potency): 21.3%
Compound 3: middle estimate off by 4.3 percentage points, on the low side; low and high end bracket the measured number.
By their numbers in this assay, from the lowest: compounds 1, 2 and 3 (each within the scatter of the next).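

At the double-bonded chain carbon bound to a double-bonded ring carbon, the exchange of a whole aryl group now has a recorded outcome: in this assay, 3-bromophenyl in place of 4-methylphenyl gives a number 5 percentage points higher from compound 1 to compound 3 (within the scatter), and 3-bromophenyl in place of 4-hydroxyphenyl gives a number 1.4 percentage points higher from compound 2 to compound 3 (within the scatter). The earlier step had compared only the 4-methylphenyl and 4-hydroxyphenyl groups, whereas all three aryl groups at this place, including one with a bromine at the 3-position named in 3-bromophenyl, now give numbers that cannot be told apart, so this read-out does not separate them. The evidence at hand offers no explanation for this flat outcome.

The three compounds leave open whether an amine or a carboxylic acid on this aromatic ring, or a longer chain in place of the aryl group, would produce a step beyond the scatter in this assay. They also cannot show how far this read-out depends on the rest of the shared core, which stays the same in compound 1, compound 2 and compound 3.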